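Terphenyl benzimidazoles: removing methoxy groups in ZR-75-1 cells

The compounds below may be only part of what the source reports. "The series", "measured", "known", "first", "only" and "open" are said of these compounds alone.

Of the compounds shown here, three sharing a terphenyl backbone carrying a benzimidazole have been measured in a functional assay on ZR-75-1 cells (Homo sapiens) for inhibition, read by sulforhodamine B assay; on this read-out higher numbers stand for weaker inhibition of growth and lower numbers for stronger inhibition of growth. Compound 1 `COc1ccc(-c2ccc(-c3ccc(-c4nc5cc(C)ccc5[nH]4)cc3)cc2)cc1OC` gives 3100 nM in this assay. Compound 3 `COc1ccc(-c2ccc(-c3ccc(-c4nc5c(O)cccc5[nH]4)cc3)cc2)cc1OC` has a core that differs from that of compound 1; the difference, seen from compound 3 to compound 1, is 5-methyl-1H-benzimidazol-2-yl in place of 4-hydroxy-1H-benzimidazol-2-yl on an aromatic carbon. In this assay compound 3 gives 2110 nM; the step of a 1.5-fold lower number from compound 1 to compound 3 (0.17 log units; within the scatter) is small. Compound 2 `Oc1cccc2[nH]c(-c3ccc(-c4ccc(-c5ccccc5)cc4)cc3)nc12` has the core of compound 3. In this assay compound 2 gives 35600 nM; the change phenyl in place of 3,4-dimethoxyphenyl on an aromatic carbon led to a 17-fold higher number from compound 3 to compound 2 (1.23 log units; beyond the scatter).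

Compound 4 `Cc1ccc2[nH]c(-c3ccc(-c4ccc(-c5ccccc5)cc4)cc3)nc2c1` has not yet been measured in this assay. It carries the core of compound 1, and it differs from compound 1 by phenyl in place of 3,4-dimethoxyphenyl on an aromatic carbon. For the measured compounds named here, this is the same change as the one from compound 3 to compound 2, made at a place described in the same words, and it occurs twice among the four compounds. Going by the values given here, the single measured instance of this change was large, so compound 4 is expected to be a weaker inhibitor of growth than compound 1 by roughly a comparable amount, estimated as a 15-fold higher number from compound 1 to compound 4 (1.16 log units; beyond the scatter); this expectation rests on the step of a 17-fold higher number from compound 3 to compound 2 (1.23 log units; beyond the scatter) and on the value of compound 1, 3100 nM. Among the compounds with values here, only one measured pair supports the size of this step, and the cores differ as told by 5-methyl-1H-benzimidazol-2-yl in place of 4-hydroxy-1H-benzimidazol-2-yl on an aromatic carbon. The range is therefore kept wide. Compound 4 is therefore estimated at 45000 nM in this assay, within a range from 15000 nM to 120000 nM.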

Compound 4, concentration for 50% growth inhibition: 27400 nM
The estimate for compound 4 lay 1.6-fold (0.22 log units) above the measured number; the range from low to high includes it.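

In this assay, phenyl in place of 3,4-dimethoxyphenyl on the core of compound 1 gave an 8.8-fold higher number from compound 1 to compound 4 (0.95 log units; beyond the scatter), so growth inhibition weakened on this core as it had on the core of compound 3. Within this series, the change therefore carried from one core to the other, and the two steps cannot be told apart in size: the same change on two cores in this assay, a 17-fold higher number (1.23 log units; beyond the scatter) from compound 3 to compound 2 and an 8.8-fold higher number (0.95 log units; beyond the scatter) from compound 1 to compound 4, 1.9-fold (0.28 log units) apart, within the scatter of two such steps This agreement rests on only two pairs, so it does not show that the step would hold on any further core; in both pairs the two methoxy groups leave together, so the data cannot tell how much of the step belongs to each of them, or whether the loss of the oxygen atoms or of the heavy atoms as such is what counts.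

The compounds shown leave open what a single methoxy group on that ring would do, since every aryl group here carries either both methoxy groups or neither. They also leave open whether an amine, a carboxylic acid or a longer alkoxy chain in place of the methoxy groups would give a number nearer to that of compound 3 or to that of compound 2.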